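The source may report more compounds than this note shows. Statements on the series, on what has been measured and on what is new or still open speak of the compounds shown alone.

In a physicochemical assay for lipophilicity (on this read-out higher numbers stand for higher lipophilicity and lower numbers for lower lipophilicity), compound 3 `COc1cc(Cn2c(=O)cc(N3CCC[C@@H](N)C3)n(Cc3cc(F)ccc3C#N)c2=O)c(Br)c(Br)c1OC` stands highest of the three measured compounds (at 4.32). Compound 2 `COc1cc(Cn2c(=O)cc(N3CCC[C@@H](N)C3)n(Cc3cc(F)ccc3C#N)c2=O)cc(Br)c1OC` lies lower (at 3.49), and compound 1 `CC#CCn1c(N2CCC[C@@H](N)C2)cc(=O)n(Cc2cc(C)cc(C)c2)c1=O` lies lowest (at 2.78). The unmeasured compound 4 `Cc1cc(C)cc(Cn2c(=O)cc(N3CCC[C@@H](N)C3)n(Cc3cc(F)ccc3C#N)c2=O)c1` has 3,5-dimethylphenyl in place of 2,3-dibromo-4,5-dimethoxyphenyl on a saturated chain carbon bound to an aromatic nitrogen. Within the data shown here, one measured step bears directly on this change: putting bromo in place of hydrogen on an aromatic carbon gave a number 0.83 log units higher from compound 2 to compound 3 (beyond the scatter) as its result. Compound 4 carries no bromo, which points to a lower number than for compound 3. Among the measured compounds shown here, no measured step covers the loss of the methoxy groups or the arrival of the methyl groups, however, so part of that fall may be offset. A downward move of modest size, beyond the scatter, is therefore expected in this assay. The estimated change is a number 0.72 log units lower from compound 3 to compound 4 (beyond the scatter) in size and direction. For compound 4 the expected value is 3.6 (estimated range 3.1 to 4.1).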

Compound 4, partition coefficient: 3.89
Compound 4: the middle estimate sits 0.29 log units below what was measured; the measured number falls inside the stated range.
By their numbers in this assay, from the lowest: compound 1; then compound 2; then compound 4; then compound 3.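

In this assay the 3,5-dimethylphenyl group gives a number 0.43 log units lower from compound 3 to compound 4 (beyond the scatter) but also a number 0.40 log units higher from compound 2 to compound 4 (beyond the scatter) when it replaces 3-bromo-4,5-dimethoxyphenyl, so at this place a ring with no bromo need not give the lowest number. Bromo alone therefore does not set the order: compound 4 carries none, yet it stands above compound 2, which carries one. A change at another place gives a bigger move, as a number 1.11 log units higher from compound 1 to compound 4 (beyond the scatter) comes with 2-cyano-5-fluorophenyl in place of prop-1-yn-1-yl.

Nothing available explains the sizes of these steps. Also open, from the compounds shown here alone, is where this assay would place compounds with an amine or a carboxylic acid on this ring, or with a longer chain in place of the ring.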